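This account rests on a few compounds, and the source may have more. Where it says the series, first, only, none or still open, it means among the compounds named here.

Of the compounds shown here, three of a shared core have been measured in a functional assay on PC-3 cells (Homo sapiens) for inhibition, read by sulforhodamine B assay, with a stated time of 48 h; on this read-out higher numbers stand for weaker inhibition of growth and lower numbers for stronger inhibition of growth. Compound 1 `CCOC(=O)C1=C(C)NC(=O)NC1c1ccc(SC)cc1` gives 9.5 ug/mL. Compound 2 `CCOC(=O)C1=C(C)NC(=S)NC1c1ccc(F)cc1` gives 1.7 ug/mL. Compound 3 `CCCc1ccc(C2NC(=S)NC(C)=C2C(=O)OCC)cc1` gives 42.4 ug/mL, the highest of the three numbers; compound 1 sits closest to it, and compound 2 farthest away.

Going by the values given here, only one measured step changes a single place: a 25-fold higher number from compound 2 to compound 3 (1.40 log units; beyond the scatter). That step, which swapped a small group on the aromatic ring for a three-carbon chain, was large and weakened growth inhibition markedly. Compound 1 and compound 3 differ in two places at once, so their values can only be compared directly, and they show compound 1 at a lower number.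

Compound 4 `CCOC(=O)C1=C(C)NC(=S)NC1c1ccc(OC)cc1` has not yet been measured. It differs from compound 3 by methoxy in place of propyl on an aromatic carbon. The step from compound 2 to compound 3 bears on this change, since it shows how sensitive this assay is to what sits at this position of the ring: moving from fluoro to propyl raised the number greatly. Replacing propyl with a two-atom methoxy group, which carries one hydrogen-bond acceptor, is therefore expected to move the number back downward, though by less than the full amount seen before, since methoxy is not fluoro. The estimated step is a 7.1-fold lower number from compound 3 to compound 4 (0.85 log units; beyond the scatter), and compound 4 is expected to give about 6 ug/mL, with a range from 1.5 ug/mL to 25 ug/mL.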

Compound 4, concentration for 50% growth inhibition: 5.5 ug/mL
Compound 4: the middle estimate sits 1.1-fold (0.04 log units) above what was measured; measured number inside the range.
By their numbers in this assay, from the lowest: compound 2; then compounds 4 and 1 (each within the scatter of the next); then compound 3.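

With compound 4, this place on the aromatic ring now carries three different groups on an otherwise unchanged core, and in this assay they give three clearly separated results. Methoxy in place of propyl gives a 7.7-fold lower number from compound 3 to compound 4 (0.89 log units; beyond the scatter) and so regains much of the growth inhibition lost with propyl, whereas methoxy in place of fluoro gives a 3.2-fold higher number from compound 2 to compound 4 (0.51 log units; beyond the scatter) and so does not regain all of it. The position therefore does more than separate fluoro from everything else: among these three compounds, fluoro gives the lowest number, methoxy the next and propyl the highest, although three groups are too few to establish a trend.

Going by these compounds, it remains open where groups such as chloro, hydroxy, an amine, a carboxylic acid, ethyl or a longer chain like butyl would fall in this order, and whether a shorter chain would lessen the loss seen with propyl. The measurements shown also contain nothing that explains the order of these three groups, so the reason for it remains unknown.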